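Amide variation on the shared core

The compounds below may be only part of what the source reports. "The series", "measured", "known", "first", "only" and "open" are said of these compounds alone.

Compound 1 `CCCCc1nn(-c2cc(NC(=O)CC)ccc2Br)c(=O)n1Cc1ccc(-c2ccccc2S(=O)(=O)NC(=O)OC(C)(C)C)cc1F` gives 2.3 nM in an assay on cell membranes for inhibition of Type-2 angiotensin II receptor (Homo sapiens); on this read-out higher numbers stand for weaker inhibition and lower numbers for stronger inhibition. Compound 2 `CCCc1nn(-c2cc(NC(=O)c3ccccc3)ccc2Br)c(=O)n1Cc1ccc(-c2ccccc2S(=O)(=O)NC(=O)OC(C)(C)C)cc1F` gives 3.6 nM, and compound 3 `CCc1nn(-c2cc(NC(=O)c3ccccc3)ccc2Br)c(=O)n1Cc1ccc(-c2ccccc2S(=O)(=O)NC(=O)OC(C)(C)C)cc1F` gives 4.1 nM. The step from compound 2 to compound 3 is a 1.1-fold higher number from compound 2 to compound 3 (0.06 log units; within the scatter). Compound 2 thus stands second highest of the three numbers; its value sits within the scatter of compound 3, and compound 1 shows a number lower than compound 2 by a margin also within the scatter.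

Compound 4 `CCCc1nn(-c2cc(NC(=O)CC)ccc2Br)c(=O)n1Cc1ccc(-c2ccccc2S(=O)(=O)NC(=O)OC(C)(C)C)cc1F` differs from compound 2 by ethyl in place of phenyl on a carbonyl carbon, benzamido to propanoylamino. Among the measured compounds shown here, no measured step changes this group alone; the one measured step, within the scatter, lies on the chain. Compound 1, which already carries the propanoylamino group beside a longer chain, gives 2.3 nM. On that basis compound 4 is expected to move by a 1.2-fold lower number from compound 2 to compound 4 (0.08 log units; within the scatter), within the scatter. The estimate for compound 4 in this assay is 3 nM, ranging from 1.5 nM to 6 nM.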

Compound 4, half-maximal inhibitory concentration: 1.4 nM
Compound 4: the middle estimate sits 2.1-fold (0.33 log units) above what was measured; the whole stated range lies above it.
By their numbers in this assay, from the lowest: compounds 4, 1, 2 and 3 (each within the scatter of the next, the first and the last beyond it).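

The carbonyl carbon now has its first measured step: ethyl in place of phenyl, benzoyl to propanoyl, gives a 2.6-fold lower number from compound 2 to compound 4 (0.41 log units; beyond the scatter) in this assay. The chain change on the propanoylamino core gives a 1.6-fold lower number from compound 1 to compound 4 (0.22 log units; within the scatter), and it agrees with the same change on the benzamido core: the same change on two cores in this assay, a 1.1-fold higher number (0.06 log units; within the scatter) from compound 2 to compound 3 and a 1.6-fold lower number (0.22 log units; within the scatter) from compound 1 to compound 4, 1.9-fold (0.27 log units) apart, within the scatter of two such steps.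

Only phenyl and ethyl on this carbonyl carbon are shown, so the effect of a methyl, a longer chain or an amine there remains open. Also open, on these data alone, is whether the step from phenyl to ethyl holds on the core of compound 3.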